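A few compounds are considered here, and "the series" means these few. Any claim that something is new, unique, unknown or untested is made for them only; others in the source may bear on it.

Working notes on the series. For the measured compounds named here, in a functional assay on PBMC cells (Homo sapiens) for inhibition, read by thymidine incorporation, with a stated time of 72 h (a higher number here means a weaker inhibitor, a lower number a stronger inhibitor), compound 1 `CC(=O)OC[C@H]1O[C@@H](SC(=S)C2=C(Nc3ccc(Cl)cc3Cl)CC(C)(C)CC2=O)[C@H](OC(C)=O)[C@@H](OC(C)=O)[C@@H]1OC(C)=O` gives 15.8 ug/mL and compound 2 `CC(=O)OC[C@H]1O[C@@H](SC(=S)C2=C(Nc3ccc(Cl)cc3)CC(C)(C)CC2=O)[C@H](OC(C)=O)[C@@H](OC(C)=O)[C@@H]1OC(C)=O` gives 9.9 ug/mL; the only single-point step, a 1.6-fold lower number from compound 1 to compound 2 (0.20 log units; within the scatter), does not leave the scatter. Compound 3 `CCCCCCCCCCCSC(=S)C1=C(Nc2ccc(Br)cc2)CC(C)(C)CC1=O` returns only a limit in this assay, > 50 ug/mL. Among the numbers shown, compound 2 sits at the lower of the two, but its gap to compound 1 is within the scatter, so the two cannot be ordered; the third value is the limit noted as the limit of > 50 ug/mL in this assay, at which 1 of the 3 values shown sits.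

Compound 4 `CC(=O)OC[C@H]1O[C@@H](SC(=S)C2=C(Nc3ccc(Br)cc3)CC(C)(C)CC2=O)[C@H](OC(C)=O)[C@@H](OC(C)=O)[C@@H]1OC(C)=O` differs from compound 2 by bromo in place of chloro on an aromatic carbon. Going by the values given here, no measured step exchanges one halogen for another; the one step known, from compound 1 to compound 2, removes a chloro and stays within the scatter, and compound 3 carries bromo but differs from compound 2 in more than one place and gives only a limit. The expectation for this assay is therefore no step beyond the scatter: compound 4 is estimated at 10 ug/mL, between 5 ug/mL and 20 ug/mL, an expected step of a 1.0-fold higher number from compound 2 to compound 4 (0.00 log units; within the scatter).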

Compound 4, half-maximal inhibitory concentration: 8.8 ug/mL
The estimate for compound 4 lay 1.1-fold (0.06 log units) above the measured number, and the stated range covers the measured number.
By their numbers in this assay, from the lowest: compounds 4, 2 and 1 (each within the scatter of the next). At a limit, above all of these: compound 3.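

In this assay the exchange of one halogen for another on this aromatic carbon, para to a large group, gives a 1.1-fold lower number from compound 2 to compound 4 (0.05 log units; within the scatter), so chloro and bromo cannot be told apart at this position. The wider change on the amine nitrogen, 4-bromophenyl in place of 2,4-dichlorophenyl, gives a 1.8-fold lower number from compound 1 to compound 4 (0.25 log units; within the scatter), so compound 1, compound 2 and compound 4 cannot be ordered. Nothing available bears on why these halogen changes leave the number within the scatter.

Open, on these data alone, is whether a group other than a halogen at this position, such as a methoxy, an amine or a carboxylic acid, would move the number beyond the scatter. Also open, as far as these compounds go, is what free hydroxyl groups in place of the acetates would do.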